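This account rests on a few compounds, and the source may have more. Where it says the series, first, only, none or still open, it means among the compounds named here.

Measured so far:
compound 1 `C/C=C/C(=O)CC1c2cc(OCc3cc(C)cc(C)c3)c(OCc3cc(C)cc(C)c3)cc2CCN1C(=O)OC(C)(C)C` — > 20000 nM
compound 2 `CCC[C@@H]1CC(=O)C/C=C(/CC)[C@H]2c3cc(OCc4ccccc4)c(OCc4ccccc4)cc3CCN12` — > 20000 nM

The compounds were tested in a functional assay on PC-3 cells (Homo sapiens) for inhibition, read by MTT assay, with a stated time of 24 h; on this read-out higher numbers stand for weaker inhibition and lower numbers for stronger inhibition. In this assay compound 1 gives only a limit, > 20000 nM, not a number. Compound 2 gives a limit as well, > 20000 nM, in this assay. So compound 1 stands nowhere above the others on the numbers shown: the limit of > 20000 nM in this assay, at which 2 of the 2 values shown sit, and neither compound reached a measurable inhibition of the cells.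

Compound 3 `Cc1cc(C)cc(COc2cc3c(cc2OCc2cc(C)cc(C)c2)CN(C(=O)OC(C)(C)C)CC3)c1` has not yet been tested. It differs from compound 1 in one place: hydrogen in place of ((prop-1-en-1-yl)carbonyl)methyl on a saturated ring carbon. Among the compounds with values here, no step between measured compounds exists here, so nothing shows how this part of the structure affects the read-out. With compound 1 already at the limit, the expectation for compound 3 is that the step that the limit leaves unreadable from compound 1 to compound 3 in this assay stays within the scatter, with no direction that can be told, and that the result will most likely again be a limit rather than a number. Compound 3 is therefore estimated at 30000 nM in this assay, within 10000 nM to 100000 nM.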

Compound 3, half-maximal inhibitory concentration: > 20000 nM
Compound 3 was reported as a limit; the forecaster's own chance of this, stated with the estimate: 85%; the middle value lies beyond the limit too.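

In this assay compound 3 gives > 20000 nM, which is a limit and not a number. Compound 1 also gave only a limit, so no step from compound 1 to compound 3 can be read: the limit of > 20000 nM in this assay, at which 3 of the 3 values shown sit.

The compounds shown leave open whether hydrogen in place of ((prop-1-en-1-yl)carbonyl)methyl changes inhibition of these cells at all.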